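The compounds below may be only part of what the source reports. "The series", "measured", "known", "first", "only" and "open" are said of these compounds alone.

Compound 1, `CC(C)Cc1ccc2c(NCCCNCc3ccco3)ccnc2c1`: 9.47
Compound 2, `COc1cccc(CNCCCNc2ccnc3cc(Oc4ccc(Cl)cc4)ccc23)c1O`: 9.28
Compound 3, `COc1ccc(F)cc1CNCCCNc1ccnc2cc(CC(C)C)ccc12`: 9.47

In a physicochemical assay for acid dissociation, compound 1 gives 9.47. Going by the values given here, compound 3 gives 9.47, and the step from one to the other, no change at the digits printed from compound 1 to compound 3 (within the scatter), is the only single-point change among the measured compounds. Compound 2 gives 9.28, a number within the scatter of the value of compound 1, so the three measured compounds sit together with no difference beyond the scatter.

The next compound, compound 4, `Cc1cc(C)cc(Cc2ccc3c(NCCCNCc4ccco4)ccnc3c2)c1`, differs from compound 1 in one place: 3,5-dimethylphenyl in place of isopropyl on a saturated chain carbon bound to an aromatic carbon. Among the compounds with values here, no measured step alters this part of the shared core. Within the data shown here, the one step that is known, no change at the digits printed from compound 1 to compound 3 (within the scatter), changed a group on a saturated chain carbon bound to an amine nitrogen and stayed within the scatter; nothing among the measured compounds points to a shift in this assay for a change elsewhere. The chemist therefore expects a number 0.02 log units lower from compound 1 to compound 4 (within the scatter) for compound 4, nothing beyond the scatter. Her estimate for compound 4 is 9.45, between 9.15 and 9.75.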

Compound 4, acid dissociation constant: 9.47
Compound 4: middle estimate off by 0.02 log units, on the low side, and the stated range covers the measured number.
By their numbers in this assay, from the lowest: compounds 2, 1, 3 and 4 (each within the scatter of the next).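

In this assay, 3,5-dimethylphenyl in place of isopropyl on a saturated chain carbon bound to an aromatic carbon gives no change at the digits printed from compound 1 to compound 4 (within the scatter). Going by these compounds alone, this is the only measured change at this position, and it shows that a group of 8 heavy atoms with one six-membered aromatic ring can replace a group of 3 heavy atoms with no ring while the read-out stays within the scatter, as it also did for the change on a saturated chain carbon bound to an amine nitrogen, no change at the digits printed from compound 1 to compound 3 (within the scatter). The compounds shown leave open whether an amine or a carboxylic acid at this position would also stay within the scatter. Nothing available offers an explanation for the absence of a shift.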